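A nitrile in place of two chlorines

The source may report more compounds than this note shows. Statements on the series, on what has been measured and on what is new or still open speak of the compounds shown alone.

The compounds measured so far:
Compound 1, `Cc1cccc(Cn2cc(COc3ccc4c(=O)ccoc4c3)nn2)c1`, gives 11700 nM in a functional assay on SW480 cells (Homo sapiens) for cytotoxicity, read by MTT assay, with a stated time of 48 h; on this read-out higher numbers stand for weaker inhibition and lower numbers for stronger inhibition.
Compound 2, `O=c1ccoc2cc(OCc3cn(Cc4ccc(Cl)cc4Cl)nn3)ccc12`, reaches only the assay limit of > 100000 nM in this assay.
Compound 3, `O=c1ccoc2cc(OCc3cn(Cc4cccc(F)c4)nn3)ccc12`, likewise reaches only the assay limit of > 100000 nM in this assay.
Compound 4, `N#Cc1cccc(Cn2cc(COc3ccc4c(=O)ccoc4c3)nn2)c1`, is not yet measured.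

Compound 2 stands at the limit of > 100000 nM in this assay, at which 2 of the 3 values shown sit, so its number is not known, only that limit. The step to compound 4 is 3-cyanophenyl in place of 2,4-dichlorophenyl on a saturated chain carbon bound to an aromatic nitrogen. For the measured compounds named here, two measured steps bear on it. The first is an at least 8.5-fold higher number from compound 1 to compound 2 (0.93 log units; beyond the scatter). The second is an at least 8.5-fold higher number from compound 1 to compound 3 (0.93 log units; beyond the scatter). The third, a step that the two limits leave unreadable from compound 2 to compound 3, cannot be read because both ends are limits. Compound 4 carries a 3-cyanophenyl, a single substituent in the same position as the 3-methylphenyl of compound 1 and the 3-fluorophenyl of compound 3, and those two gave one readable value and one limit. Compound 4 is therefore expected to show an at least 2.5-fold lower number from compound 2 to compound 4 (0.39 log units; beyond the scatter), but a limit again is a real possibility. The estimate for compound 4 is 40000 nM, with a range from 8000 nM to 200000 nM.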

Compound 4, half-maximal inhibitory concentration: > 100000 nM
Compound 4 ended at the assay's limit; the forecaster's own chance of this, stated with the estimate: 50%; middle value at least 2.5-fold (0.39 log units) away from the limit.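

In this assay compound 4 gives > 100000 nM, which is a limit of the assay and not a number. For the compounds shown here, the one step to it that can be read is an at least 8.5-fold higher number from compound 1 to compound 4 (0.93 log units; beyond the scatter), and the steps reaching compound 4 from compound 2 and from compound 3 cannot be read, since both ends of each are limits. Compound 1 is now the only one of the four with a readable value, so 3-methylphenyl stands alone, while 3-fluorophenyl, 3-cyanophenyl and 2,4-dichlorophenyl share one limit: the limit of > 100000 nM in this assay, at which 3 of the 4 values shown sit.

From the compounds shown here alone, how far compound 2, compound 3 and compound 4 lie beyond that limit remains open. Also open, going by these compounds, is whether a readable value depends on the methyl itself or would return with a 3-ethylphenyl or a 3-methoxyphenyl.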